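This account rests on a few compounds, and the source may have more. Where it says the series, first, only, none or still open, it means among the compounds named here.

Measured so far in a functional assay on P388 cells (Mus musculus) for inhibition; on this read-out higher numbers stand for weaker inhibition and lower numbers for stronger inhibition:
- compound 1 `COCCOc1cc(/C=C/c2ccc3ccccc3c2)ccc1OC` gives 2990 nM
- compound 2 `COc1ccc(/C=C/c2ccc3ccccc3c2)cc1F` gives 4490 nM
- compound 3 `COc1ccc(/C=C/c2ccc3ccccc3c2)cc1N` gives > 5000 nM (a limit)

Compound 3 stands at > 5000 nM in this assay, which is a limit and not a number. This is the only entry of its kind in the set: the limit of > 5000 nM in this assay, at which 1 of the 3 values shown sits, applies to it. It therefore cannot be placed exactly against compound 1 or compound 2.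

The next step leads to compound 4 `COc1c(N)cc(/C=C/c2ccc3ccccc3c2)cc1N`, with amino in place of hydrogen on an aromatic carbon is the change.

Among the measured compounds shown here, three measured steps bear on this only indirectly, since each swaps one group for another and none replaces hydrogen with amino. They are a 1.5-fold higher number from compound 1 to compound 2 (0.18 log units; within the scatter), an at least 1.6-fold higher number from compound 1 to compound 3 (0.22 log units; that floor lies within the scatter) and an at least 1.1-fold higher number from compound 2 to compound 3 (0.04 log units; that floor lies within the scatter) and all stay within the scatter, the last two only as floors. Going by these compounds, on that evidence, no step beyond the scatter is expected in this assay, in either direction, though the true size remains open given the limit for compound 3. The expected step is a step that the limit leaves unreadable from compound 3 to compound 4 as estimated here. For compound 4 the estimated value is 5500 nM, with an expected range from 2000 nM to 15000 nM and a real chance of another limit.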

Compound 4, half-maximal inhibitory concentration: > 5000 nM
Compound 4: no number, only a limit; the forecaster's own chance of this, stated with the estimate: 55%; the middle value lies beyond the limit too.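

Compound 3 and compound 4 both stand at a limit in this assay, so no step between them can be read: the limit of > 5000 nM in this assay, at which 2 of the 4 values shown sit.

The compounds shown leave open whether amino in place of hydrogen on an aromatic carbon changes inhibition at all, and if so, in which direction and by how much.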